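This account rests on a few compounds, and the source may have more. Where it says the series, first, only, none or still open, it means among the compounds named here.

Three related compounds share a core carrying a five-membered aromatic ring, and they differ only in the group attached to it. Compound 1 `Cc1ncc([N+](=O)[O-])n1CCSc1nnc(-c2ccccc2)o1` bears a phenyl, compound 2 `Cc1ncc([N+](=O)[O-])n1CCSc1nnc(-c2ccccc2N)o1` a 2-aminophenyl, and compound 3 `Cc1ncc([N+](=O)[O-])n1CCSc1nnc(-c2cccnc2)o1` a pyridin-3-yl. In a functional assay on SGC-7901 cells (Homo sapiens) for cytotoxicity, read by MTT assay, with a stated time of 48 h (on this read-out higher numbers stand for weaker inhibition and lower numbers for stronger inhibition), compound 1 gives 30100 nM, compound 2 gives 35100 nM, and compound 3 gives 31600 nM. Placing an amino in place of hydrogen on an aromatic carbon gave a 1.2-fold higher number from compound 1 to compound 2 (0.07 log units; within the scatter). The core of compound 3 differs from that of compound 1 by the aromatic group (pyridin-3-yl in place of phenyl on an aromatic carbon).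

Compound 4 `Cc1ncc([N+](=O)[O-])n1CCSc1nnc(-c2cnccc2N)o1` has not yet been measured. It arises from compound 3 by the same kind of change (amino in place of hydrogen on an aromatic carbon); here the place is on a six-membered aromatic ring with 1 nitrogen, opposite the ring nitrogen, whereas in compound 2 it is on a ring of carbon only, though both are ortho to a large group. Because the earlier step of a 1.2-fold higher number from compound 1 to compound 2 (0.07 log units; within the scatter) stayed within the scatter, a step of about a 1.2-fold higher number from compound 3 to compound 4 (0.07 log units; within the scatter) in this assay is expected for compound 4. Compound 4 is therefore estimated at 37000 nM, most likely between 20000 nM and 70000 nM.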

Compound 4, half-maximal inhibitory concentration: 34500 nM
Estimate against measurement, compound 4: 1.1-fold (0.03 log units) above, within the range that was stated.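

In this assay, placing an amino on the aromatic ring gives a step within the scatter on both cores, and the two steps agree: the same change on two cores in this assay, a 1.2-fold higher number (0.07 log units; within the scatter) from compound 1 to compound 2 and a 1.1-fold higher number (0.04 log units; within the scatter) from compound 3 to compound 4, 1.1-fold (0.03 log units) apart, within the scatter of two such steps. The three comparisons with compound 4 also stay within the scatter, at a 1.1-fold higher number from compound 3 to compound 4 (0.04 log units; within the scatter) and a 1.0-fold lower number from compound 2 to compound 4 (0.01 log units; within the scatter) and a 1.1-fold higher number from compound 1 to compound 4 (0.06 log units; within the scatter). So on these two cores the amino change carries over with the same outcome, a step too small to tell from repeat-measurement noise, but this does not show that the amino has no effect at all, nor that the same would hold on any other core or at another place on the ring.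

Going by these compounds, it remains open whether a different group at this place, such as a methoxy, a chlorine or a carboxylic acid, would give a step beyond the scatter. The compounds shown also leave open whether changes elsewhere in the shared core, such as a longer chain in place of the present link, would move the number more.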